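Benzylthio to pentylthio on a shared selenium-containing core

The source may report more compounds than this note shows. Statements on the series, on what has been measured and on what is new or still open speak of the compounds shown alone.

Measured so far:
compound 1 `O=c1c2ccccc2[se]n1-c1nc(SCc2ccccc2)n[nH]1` with 32000 nM
compound 2 `Cc1cccc(CSc2n[nH]c(-n3[se]c4ccccc4c3=O)n2)c1` with 9040 nM
compound 3 `O=c1c2ccccc2[se]n1-c1nc(SCc2ccc(F)cc2)n[nH]1` with 46100 nM

In a functional assay on SMMC-7721 cells (Homo sapiens) for antiproliferative activity, read by CCK-8 assay, with a stated time of 48 h (on this read-out lower numbers stand for stronger inhibition and higher numbers for weaker inhibition), compound 3 gives the highest of the three numbers. Its nearest neighbour is compound 1, which gives 32000 nM; that gap, a 1.4-fold higher number from compound 1 to compound 3 (0.16 log units; within the scatter), lies within the scatter, so the two cannot be ordered. Compound 2 gives 9040 nM, and the gap a 5.1-fold higher number from compound 2 to compound 3 (0.71 log units; beyond the scatter) is beyond the scatter.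

Compound 4 `CCCCCSc1n[nH]c(-n2[se]c3ccccc3c2=O)n1` differs from compound 3 in one place: butyl in place of 4-fluorophenyl on a saturated chain carbon bound to a sulfur. The measured steps all concern the group on the saturated chain carbon bound to a sulfur, but each of them swaps one six-membered aromatic ring for another: a 3.5-fold lower number from compound 1 to compound 2 (0.55 log units; beyond the scatter) and a 1.4-fold higher number from compound 1 to compound 3 (0.16 log units; within the scatter). For the measured compounds named here, no measured step removes the ring and puts a chain in its place, so nothing measured speaks directly to this change. The expectation is therefore anchored on compound 3 and compound 1, with wide room on either side, and the step of a 1.5-fold lower number from compound 3 to compound 4 (0.19 log units; within the scatter) in this assay is estimated to stay within the scatter. Compound 4 is expected to give about 30000 nM, within a range from 8000 nM to 120000 nM.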

Compound 4, half-maximal inhibitory concentration: 31400 nM
Beside the measured number, compound 4's estimate is 1.0-fold (0.02 log units) below it, and the stated range covers the measured number.
By their numbers in this assay, from the lowest: compound 2; then compounds 4, 1 and 3 (each within the scatter of the next).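

In this assay, for the compounds shown here, the earlier compounds only swapped one aromatic ring for another, whereas compound 4 shows what happens when the ring gives way to a chain, with butyl in place of 4-fluorophenyl on a saturated chain carbon bound to a sulfur (a 1.5-fold lower number from compound 3 to compound 4 (0.17 log units; within the scatter)) and butyl in place of phenyl at the same place (a 1.0-fold lower number from compound 1 to compound 4 (0.01 log units; within the scatter)). Both steps stay within the scatter, so at this position in these compounds the aromatic ring can be exchanged for butyl with no readable change, and compound 4 cannot be ordered against compound 1 or compound 3. Butyl in place of 3-methylphenyl (a 3.5-fold higher number from compound 2 to compound 4 (0.54 log units; beyond the scatter)) lies beyond the scatter, which leaves compound 2 as the only one of the four set apart from the rest, although no measurement offered here explains the result.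

The compounds shown leave open how a longer chain, or a chain bearing an amine or a carboxylic acid, would read in place of butyl. They also leave open whether the separate standing of compound 2 is tied to the methyl on its ring, as compound 2 alone carries that group.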